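The source may report more compounds than this note shows. Statements on the series, on what has been measured and on what is new or still open speak of the compounds shown alone.

In a functional assay on U-87MG ATCC cells (Homo sapiens) for cytotoxicity, read by MTT assay, with a stated time of 48 h (a higher number here means a weaker inhibitor, a lower number a stronger inhibitor), compound 2 `C/C(=N/NC(=S)Nc1ccccc1)c1ccccn1` gives 1.4 nM and compound 1 `C/C(=N\NC(=S)Nc1ccc(Cl)cc1)c1ccccn1` gives 1.7 nM as values within the scatter of each other, while compound 3 `C/C(=N/NC(=S)Nc1cccc([N+](=O)[O-])c1)c1ccccn1` gives 69 nM and stands well apart from both. Compound 2 therefore sits at the low end of the numbers shown, level with compound 1. The change leading to compound 4 `C/C(=N/NC(=S)Nc1ccc(Cl)cc1)c1ccccn1` is chloro in place of hydrogen on an aromatic carbon with chloro in place of hydrogen on an aromatic carbon, para to a large group. For the measured compounds named here, the one measured step, a 49-fold higher number from compound 2 to compound 3 (1.69 log units; beyond the scatter) for nitro in place of hydrogen, is large but involves a different group, so it sets no size for chloro. Compound 1 is closer, carrying the same chloro group with the opposite geometry at the double bond and giving 1.7 nM within the scatter of compound 2. A step beyond the scatter is therefore not expected in this assay and any drift is expected to be slightly upward. The expected step is a 1.6-fold higher number from compound 2 to compound 4 (0.20 log units; within the scatter) and it remains an estimate only. For compound 4 the estimated value is 2.2 nM with an expected range from 0.7 nM to 9 nM in this series.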

Compound 4, half-maximal inhibitory concentration: 1.7 nM
Compound 4: the middle estimate sits 1.3-fold (0.11 log units) above what was measured; measured number inside the range.
By their numbers in this assay, from the lowest: compounds 2, 1 and 4 (each within the scatter of the next); then compound 3.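

In this assay, chloro in place of hydrogen on an aromatic carbon, para to a large group, gives a step within the scatter: a 1.2-fold higher number from compound 2 to compound 4 (0.08 log units; within the scatter). This position therefore accepts chloro with no readable shift, so the large step seen for the nitro compound does not extend to every replacement of hydrogen on this ring. The drawn geometry at the double bond also makes no readable difference, with no change at the digits printed from compound 1 to compound 4 (within the scatter), and this pair isolates that single feature: the fact that compounds 1 and 4 differ only in the configuration as drawn

On these data alone, whether an amine or a carboxylic acid on this same aromatic carbon would stay level with compound 2 or move as far as compound 3 remains open. As far as these compounds go, it is also open whether the double bond geometry would prove equally silent with hydrogen in place of chloro.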